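A few compounds are considered here, and "the series" means these few. Any claim that something is new, unique, unknown or untested is made for them only; others in the source may bear on it.

Of the compounds shown here, three sharing the same core have been measured in a functional assay on PC-3 cells (Homo sapiens) for antiproliferative activity, read by MTT assay, with a stated time of 48 h; on this read-out higher numbers stand for weaker inhibition and lower numbers for stronger inhibition. Compound 1 `C=C(/C=C/c1ccc(OC)c(O)c1)c1cc(OC)c(OC)c(OC)c1` gives 423 nM in this assay. Compound 2 `CO/C=C(\C=C\c1ccc(OC)c(O)c1)c1cc(OC)c(OC)c(OC)c1` gives 5330 nM in this assay. Compound 3 `CC=C(/C(C)=C/c1ccc(OC)c(O)c1)c1cc(OC)c(OC)c(OC)c1` gives 789 nM in this assay. Among these three numbers, compound 3 holds the second highest; its number and that of compound 1 lie within the scatter of each other, while the number of compound 2 stands clearly higher than that of compound 3.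

Compound 4 `CCCC=C(/C(C)=C/c1ccc(OC)c(O)c1)c1cc(OC)c(OC)c(OC)c1` is not yet measured. It differs from compound 3 in one place: ethyl in place of hydrogen on a saturated chain carbon bound to a double-bonded chain carbon, so that the chain is lengthened from methyl to propyl. Among the compounds with values here, no pair among the measured compounds shows what such a lengthening does here, so the expectation rests on little. The step from compound 3 to compound 4 is expected to be small, most likely a modest rise in the number, of size a 1.5-fold higher number from compound 3 to compound 4 (0.18 log units; within the scatter), and it may well stay within the scatter. Compound 4 is estimated to give 1200 nM in this assay, within a range from 400 nM to 4000 nM.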

Compound 4, half-maximal inhibitory concentration: 4510 nM
Compound 4: the middle estimate sits 3.8-fold (0.57 log units) below what was measured; the measured number lies above the stated range.
By their numbers in this assay, from the lowest: compounds 1 and 3 (each within the scatter of the next); then compounds 4 and 2 (each within the scatter of the next).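

Lengthening the chain from methyl to propyl, on a saturated chain carbon bound to a double-bonded chain carbon, is not a neutral change: in this assay it gives a 5.7-fold higher number from compound 3 to compound 4 (0.76 log units; beyond the scatter), a step that means weaker inhibition of the cells. Within the data shown here, this position therefore responds to the added ethyl, something no earlier pair of compounds could show. Nothing available here says why the step occurs.

Still open, from the compounds shown here alone, is whether an ethyl chain in place of the methyl would already bring a step of this kind, or whether a longer chain such as butyl would go further in the same direction. Also open, going by these compounds, is how a chain carrying a hydroxyl or an amine would compare, so one step on this chain gives no general rule for the shared core.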